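The compounds below may be only part of what the source reports. "The series", "measured", "known", "first", "only" and "open" are said of these compounds alone.

Measured so far in an assay on isolated protein for inhibition of Nicotinamide phosphoribosyltransferase (Homo sapiens), read by mass spectrometry, with stated times of 15 min and 30 min; a higher number here means a weaker inhibitor, a lower number a stronger inhibitor:
compound 1 `O=C(NCc1ccc(S(=O)(=O)c2ccccc2)cc1)NCc1cccnc1` gives 19 nM
compound 2 `CC(=O)N1CCC(S(=O)(=O)c2ccc(CNC(=O)N3Cc4ccncc4C3)cc2)CC1` gives 83 nM

Compound 2 carries the higher of the two numbers; compound 1 sits at a lower value, and the gap between them lies beyond the usual scatter. Going by the values given here, no single-point step links the pair, so no step size is recorded for it.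

Compound 3 `O=C(NCc1ccc(S(=O)(=O)N2CCC(N3CCCC3)CC2)cc1)N1Cc2ccncc2C1` is not yet measured. It differs from compound 2 in one place: 4-(pyrrolidin-1-yl)piperidin-1-yl in place of 1-acetylpiperidin-4-yl on a sulfonyl sulfur.

Among the compounds with values here, with only two measured compounds, the expected step of a 1.4-fold lower number from compound 2 to compound 3 (0.14 log units; within the scatter) is small and within the scatter. For compound 3 the estimate is 60 nM, with a range from 15 nM to 250 nM.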

Compound 3, half-maximal inhibitory concentration: 7.4 nM
For compound 3 the middle estimate is 8.1-fold (0.91 log units) above the measured one; the measured number lies below the stated range.
By their numbers in this assay, from the lowest: compound 3; then compound 1; then compound 2.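

In this assay the group on the sulfonyl sulfur strongly sets the value, with an 11-fold lower number from compound 2 to compound 3 (1.05 log units; beyond the scatter) on replacing 1-acetylpiperidin-4-yl by 4-(pyrrolidin-1-yl)piperidin-1-yl. The change adds a five-membered non-aromatic ring and removes the double bond outside aromatic rings, while the hydrogen-bond donor and acceptor counts stay unchanged. No measurement available here explains the step.

This single step cannot separate the pyrrolidine ring from the loss of the acetyl group. A 4-(dimethylamino)piperidin-1-yl or morpholin-4-yl group on the same sulfur would help to separate them.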